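The source may report more compounds than this note shows. Statements on the series, on what has been measured and on what is new or still open speak of the compounds shown alone.

Compound 1, `COc1cccc(N2CCN(C(=O)c3oc(C(F)(F)F)nc3-c3cccc(F)c3)CC2)c1`, in a functional assay on HL-60 cells (Homo sapiens) for inhibition, read by MTT assay, with a stated time of 72 h (on this read-out lower numbers stand for stronger inhibition and higher numbers for weaker inhibition), gives "not active" (no number reported).
Compound 2, `Cc1nc(-c2ccccc2)c(C(=O)N2CCN(c3cccc(Cl)c3Cl)CC2)o1`, in this assay gives 133 nM.
Compound 3, `Cc1ccc(C)c(N2CCN(C(=O)c3oc(C)nc3-c3ccc(Cl)cc3)CC2)c1`, in this assay gives "not active" (no number reported).

Compound 2 is the only one of the three to carry a number in this assay; compound 1 and compound 3 are each reported without one. Compound 4, `Cc1nc(-c2ccccc2)c(C(=O)N2CCN(c3cc(Cl)cc(Cl)c3)CC2)o1`, shares every atom with compound 2 but joins them differently: 3,5-dichlorophenyl in place of 2,3-dichlorophenyl on an amine nitrogen in a ring. Within the data shown here, no pair of measured compounds differs in just one place, so the size of such a step in this assay has to be guessed rather than read off. The two entries without a number, compound 1 and compound 3, show that small changes on the aryl ring of this kind of core can take a compound out of range, and that leaves the outlook for compound 4 cautious. A loss of potency beyond the scatter is expected in moving from compound 2 to compound 4, and the expected step is a 3.4-fold higher number from compound 2 to compound 4 (0.53 log units; beyond the scatter). Compound 4 is therefore estimated at 450 nM in this assay, with a range from 120 nM to 2500 nM.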

Compound 4, half-maximal inhibitory concentration: 41.8 nM
Compound 4: the middle estimate sits 11-fold (1.03 log units) above what was measured, outside the stated range (below it).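

In this assay, 3,5-dichlorophenyl in place of 2,3-dichlorophenyl on an amine nitrogen in a ring gives a 3.2-fold lower number from compound 2 to compound 4 (0.50 log units; beyond the scatter), so inhibition at this position depends on how the two chlorines are arranged on the phenyl group, even with no atom gained or lost. Among these compounds, this is the first comparison here between compounds that differ in one place, and it shows that a change on this aryl group can strengthen inhibition beyond the scatter. Nothing among the data shown explains why the 3,5-dichlorophenyl compound gives the lower number.

On these data alone, it remains open whether other groups with the same arrangement, such as 3,5-difluorophenyl or 3,5-dimethylphenyl, would keep this gain. Also open, as far as these compounds go, is whether 3,5-dichlorophenyl would give a similar step with a trifluoromethyl group on the core in place of the methyl.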